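Oral Bioavailability Notes: Compound 2 and Compound 3

The compounds below may be only part of what the source reports. "The series", "measured", "known", "first", "only" and "open" are said of these compounds alone.

Measured so far in an ADME assay on the whole organism (strain Sprague-Dawley) for pharmacokinetics, with Rattus norvegicus as the target, at a dose of 5 mg/kg by the oral route; on this read-out lower numbers stand for lower oral bioavailability and higher numbers for higher oral bioavailability:
compound 1 `CC(C)c1ccc2c(Nc3cc(C(=O)N[C@@H](C)C4CCCCC4)ccc3Sc3ccc(N)cc3)ncnc2n1` gives 5%
compound 2 `CC(C)c1ccc2c(Nc3cc(C(=O)N[C@@](C)(CO)c4ccccc4)ccc3Sc3ccc(N)cc3)ncnc2n1` gives 13.3%

Within the data shown here, compound 2 holds the higher of the two numbers, but the only measured step, a number 8.3 percentage points higher from compound 1 to compound 2 (within the scatter), is within the scatter, so the two values cannot be ordered. Compound 3 `CC(C)c1ccc2c(Nc3cc(C(=O)N[C@@H](C)c4ccccc4)ccc3Sc3ccc(N)cc3)ncnc2n1` differs from compound 2 by hydrogen in place of hydroxymethyl on a saturated chain carbon bound to an amide-type nitrogen, an aromatic carbon and a saturated chain carbon. Among the measured compounds shown here, no measured step touches the hydroxymethyl; the single step known, a number 8.3 percentage points higher from compound 1 to compound 2 (within the scatter), exchanges the whole group on the amide-type nitrogen and was itself within the scatter. With nothing to point either way, compound 3 is expected near compound 2, with a number 3.3 percentage points lower from compound 2 to compound 3 (within the scatter) and a wide range. The estimate for compound 3 is 10%, between 2% and 28%.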

Compound 3, oral bioavailability in the Rattus norvegicus assay: 42.4%
Estimate against measurement, compound 3: 32.4 percentage points below; measured number above the stated range.
By their numbers in the Rattus norvegicus assay, from the lowest: compounds 1 and 2 (each within the scatter of the next); then compound 3.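

Among these compounds, in the Rattus norvegicus assay, the hydrogen in place of hydroxymethyl on this saturated chain carbon gives the first step that can be read, a number 29.1 percentage points higher from compound 2 to compound 3 (beyond the scatter), so the hydroxymethyl position is not neutral for this read-out. In the Rattus norvegicus assay, phenyl in place of cyclohexyl on the same carbon can also be read, a number 37.4 percentage points higher from compound 1 to compound 3 (beyond the scatter), which the whole-group exchange between the two earlier compounds did not allow. In a physicochemical assay for solubility (a lower number here means a less soluble compound, a higher number a more soluble compound), compound 2 gives 19700 nM and compound 3 gives 5000 nM, so this pair ranks in opposite order on the two read-outs.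

As far as these compounds go, it remains open how a methoxymethyl or aminomethyl group on this carbon would read in either assay. The compounds shown also leave open whether a pyridyl group in place of phenyl would keep the higher oral bioavailability.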